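Removing a Methyl Group from a Weak Cell-Growth Inhibitor

The compounds below may be only part of what the source reports. "The series", "measured", "known", "first", "only" and "open" are said of these compounds alone.

Four compounds share one core and differ in two places. Compound 1 `O=C(/C=C/c1coc2cc(O)ccc2c1=O)NCc1ccccc1` carries hydroxy on the core and benzyl on the amide-type nitrogen. In a functional assay (QGY7701 cells, Homo sapiens) for inhibition, read by MTT assay, with a stated time of 48 h (a higher number here means a weaker inhibitor, a lower number a stronger inhibitor), compound 1 gives 63000 nM. Compound 2 `COc1ccc2c(=O)c(/C=C/C(=O)NCc3ccccc3)coc2c1` carries methoxy instead; in this assay compound 2 reaches only the limit > 100000 nM. Compound 3 `COc1ccc(NC(=O)/C=C/c2coc3cc(OC)ccc3c2=O)cc1` likewise stops at the limit > 100000 nM in this assay. The change from compound 2 to compound 1 is hydrogen in place of methyl on an oxygen on an aromatic ring, and it made an at least 1.5-fold lower number from compound 2 to compound 1 (0.20 log units; that floor lies within the scatter). Compound 3 differs from compound 2 by 4-methoxyphenyl in place of benzyl on an amide-type nitrogen, which gave a step that the two limits leave unreadable from compound 2 to compound 3, a step that cannot be read because the limit of > 100000 nM in this assay, at which 2 of the 3 values shown sit, caps both values. Compound 4 `COc1ccc(NC(=O)/C=C/c2coc3cc(O)ccc3c2=O)cc1`, not yet measured, differs from compound 3 by hydrogen in place of methyl on an oxygen on an aromatic ring, the same change as that from compound 2 to compound 1, at the same place. In this assay the step from compound 3 to compound 4 is expected to be an at least 1.4-fold lower number from compound 3 to compound 4 (0.15 log units; that floor lies within the scatter) because the same change earlier gave an at least 1.5-fold lower number from compound 2 to compound 1 (0.20 log units; that floor lies within the scatter). Compound 4 is thus estimated at 70000 nM, within a range from 30000 nM to 150000 nM.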

Compound 4, half-maximal inhibitory concentration: > 100000 nM
Compound 4 was reported as a limit; the forecaster's own chance of this, stated with the estimate: 40%; middle value at least 1.4-fold (0.15 log units) from the limit.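

In this assay compound 4 stops at the limit > 100000 nM, which is a limit and not a number. For the compounds shown here, the methoxy to hydroxy change therefore cannot be followed onto the 4-methoxyphenyl amide, and no step with a limit at both ends can be read, because both of its compounds sit at the same cap: the limit of > 100000 nM in this assay, at which 3 of the 4 values shown sit. So the result neither shows that the change carries over from the benzyl amide nor shows that it fails there, and the one readable step, 4-methoxyphenyl in place of benzyl with hydroxy on the core, is an at least 1.5-fold higher number from compound 1 to compound 4 (0.20 log units; that floor lies within the scatter), which establishes no difference beyond the usual scatter.

As far as these compounds go, only compound 1 gives a true number here, so the size of any effect of the methoxy to hydroxy change remains unknown on either amide. Also open, from the compounds shown here alone, is how an amine in place of hydroxy on the core, or a longer chain in place of benzyl on the amide-type nitrogen, would read in this assay.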